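The compounds below may be only part of what the source reports. "The series", "measured", "known", "first", "only" and "open" are said of these compounds alone.

Three compounds have so far been measured in an ADME assay for permeability, using PAMPA, with a stated time of 30 min, at pH 7.4; a lower number here means that the compound crosses the layer more slowly, a higher number that the compound crosses the layer faster:

Compound 1, `COc1cccc(CNCCCNc2ccnc3cc(C4CCCCC4)ccc23)c1O`, gives 23 10^-6 cm/s.
Compound 2, `COc1cccc(Oc2ccc3c(NCCCNCc4cc(F)ccc4OC)ccnc3c2)c1`, gives 317 10^-6 cm/s.
Compound 3, `COc1cccc(Oc2ccc3c(NCCCNCc4ccco4)ccnc3c2)c1`, gives 317 10^-6 cm/s.

Compound 2 stands level with compound 3 at the digits shown, and the two together give the highest numbers of the three. The furthest from compound 2 is compound 1, which gives a lower number, a gap that lies beyond the scatter. The fourth compound, compound 4, `COc1ccc(F)cc1CNCCCNc1ccnc2cc(CC3CCCCC3)ccc12`, has not yet been measured in this assay. It differs from compound 2 in one place: cyclohexylmethyl in place of 3-methoxyphenoxy on an aromatic carbon.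

Among the measured compounds shown here, the one measured step, no change at the digits printed from compound 2 to compound 3 (within the scatter), changes the group on the amine side of the molecule, not the group on the aromatic carbon of the core, so it offers no direct guide to the step from compound 2 to compound 4. Compound 1 carries a cyclohexyl on that side of the core but also differs from compound 2 elsewhere. In this assay compound 1 gives 23 10^-6 cm/s, a lower number than compound 2. On that basis a lower number is expected for compound 4, with the step of a 3.2-fold lower number from compound 2 to compound 4 (0.50 log units; beyond the scatter) estimated to lie beyond the scatter. For compound 4 the estimate is 100 10^-6 cm/s, expected to fall between 25 10^-6 cm/s and 320 10^-6 cm/s.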

Compound 4, apparent permeability: 23 10^-6 cm/s
Compound 4: middle estimate off by 4.3-fold (0.64 log units), on the high side; measured number outside the range, below it.
By their numbers in this assay, from the lowest: compounds 1 and 4 (each within the scatter of the next); then compounds 2 and 3 (each within the scatter of the next).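

At the aromatic carbon of the shared core, putting cyclohexylmethyl in place of 3-methoxyphenoxy gives a 14-fold lower number from compound 2 to compound 4 (1.14 log units; beyond the scatter) in this assay, so this position is not silent in this assay. Among the compounds shown here, the only earlier step between compounds differing in one place, no change at the digits printed from compound 2 to compound 3 (within the scatter), changed the group on the amine side, which makes the new step the first reading at this aromatic carbon and the first single-place step to lie beyond the scatter. No measurement at hand accounts for the size of this step.

The change swaps a six-membered aromatic ring of carbon for a non-aromatic one and also removes the 2 hydrogen-bond acceptors of the leaving group, and the compounds shown cannot tell these apart; a cyclohexyloxy group or a benzyl group at the same carbon would separate the ring from the linking atom, and an unsubstituted phenoxy would isolate the methoxy. On these data alone, it also remains open whether the step keeps its size with furan-2-yl in place of 5-fluoro-2-methoxyphenyl on the amine side.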